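A few compounds are considered here, and "the series" means these few. Any claim that something is new, unique, unknown or untested is made for them only; others in the source may bear on it.

Measured so far in a functional assay on MX1 cells (Homo sapiens) for inhibition, read by MTT assay, with a stated time of 120 h; on this read-out higher numbers stand for weaker inhibition and lower numbers for stronger inhibition:
- compound 1 `C/C(=C\c1ccc(NC(=O)Nc2ccc(Cl)c(C(F)(F)F)c2)cc1)C(=O)NC(C)c1ccccc1`: > 50000 nM (a limit, not a number)
- compound 2 `CC(NC(=O)/C=C/c1ccc(NC(=O)Nc2ccc(Cl)c(C(F)(F)F)c2)cc1)c1ccccc1`: 3130 nM
- compound 3 `CNC(=O)/C=C/c1ccc(NC(=O)Nc2ccc(Cl)c(C(F)(F)F)c2)cc1`: 13800 nM

Of the two results that are true numbers, compound 3 has the higher, 13800 nM, and so the weaker inhibition. Its nearest neighbour is compound 2, and the step between them is a 4.4-fold higher number from compound 2 to compound 3 (0.64 log units; beyond the scatter). That step puts methyl in place of 1-phenylethyl on an amide-type nitrogen.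

Compound 4 `O=C(CCc1ccc(NC(=O)Nc2ccc(Cl)c(C(F)(F)F)c2)cc1)NC1CCC1` is not yet measured. It has 2-(cyclobutylcarbamoyl)ethyl in place of 2-(methylcarbamoyl)ethenyl on an aromatic carbon.

Only half of this change has a measured precedent. Compound 2 shows a larger group than methyl on the amide nitrogen going with a lower number, a 4.4-fold higher number from compound 2 to compound 3 (0.64 log units; beyond the scatter). Going by the values given here, no measured step covers ethenyl giving way to ethyl, so the uncertainty stays wide. Compound 1 adds only (the limit of > 50000 nM in this assay, at which 1 of the 3 values shown sits).

The expected change is a 2.0-fold lower number from compound 3 to compound 4 (0.29 log units; within the scatter), a modest one toward stronger inhibition. Compound 4 is estimated at 7000 nM, within an expected range of 2500 nM to 25000 nM.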

Compound 4, half-maximal inhibitory concentration: 24000 nM
Estimate against measurement, compound 4: 3.4-fold (0.54 log units) below; low and high end bracket the measured number.
By their numbers in this assay, from the lowest: compound 2; then compounds 3 and 4 (each within the scatter of the next). At a limit, above all of these: compound 1.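

Replacing 2-(methylcarbamoyl)ethenyl with 2-(cyclobutylcarbamoyl)ethyl on this aromatic carbon gives a 1.7-fold higher number from compound 3 to compound 4 (0.24 log units; within the scatter), so this double change shifts the result by no more than repeat measurements usually do. The gain seen earlier with a larger group on the amide nitrogen, a 4.4-fold higher number from compound 2 to compound 3 (0.64 log units; beyond the scatter), therefore does not reappear here, where a cyclobutyl group arrives together with the saturated ethyl chain. Compound 1 offers no number for comparison, only a limit: the limit of > 50000 nM in this assay, at which 1 of the 4 values shown sits.

The two parts of the change stay tangled, since no compound shown pairs the ethyl chain with a methyl amide or the ethenyl chain with a cyclobutyl amide. Going by these compounds, how a longer chain at this position, or a carboxylic acid in place of the amide, would read in this assay also remains open.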